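A few compounds are considered here, and "the series" means these few. Any claim that something is new, unique, unknown or untested is made for them only; others in the source may bear on it.

Measured compounds:

- compound 1, `COc1cc2c(Oc3ccc(NC(=O)c4cn(-c5ccccc5C)nn4)cc3F)ccnc2cc1OCCCN1CCCC1`: "not determined" (no result reported) in a functional assay on MKN-45 cells (Homo sapiens) for cytotoxicity, read by MTT assay, with a stated time of 72 h; a higher number here means a weaker inhibitor, a lower number a stronger inhibitor
- compound 2, `COc1cc2c(Oc3ccc(NC(=O)c4cn(-c5ccc(Br)cc5)nn4)cc3F)ccnc2cc1OCCCN1CCCC1`: 120 nM
- compound 3, `COc1cc2c(Oc3ccc(NC(=O)c4cn(-c5ccccc5C)nn4)cc3F)ccnc2cc1OCCCN1CCCCC1`: 3250 nM

Compound 3 stands highest of the two numbers available in this assay. The nearest is compound 2, whose value in this assay is 120 nM, a gap that lies beyond the scatter. For the measured compounds named here, compound 1 shares the same aryl group as compound 3 but differs elsewhere, and for it no number is reported, so no step between them can be read.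

Compound 4, `COc1cc2c(Oc3ccc(NC(=O)c4cn(-c5c(C)cccc5C)nn4)cc3F)ccnc2cc1OCCCN1CCCCC1`, is not yet measured. It differs from compound 3 by methyl in place of hydrogen on an aromatic carbon; cut one bond further out, the change reads 2-methylphenyl to 2,6-dimethylphenyl. Going by the values given here, no step between measured compounds matches this change, so the expectation rests on compound 3 alone, whose value in this assay is 3250 nM. A step of modest size is expected, towards a somewhat higher number or none beyond the scatter, meaning a 1.2-fold higher number from compound 3 to compound 4 (0.09 log units; within the scatter). Compound 4 is therefore estimated at 4000 nM in this assay, with a range from 1200 nM to 13000 nM.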

Compound 4, half-maximal inhibitory concentration: 2140 nM
Estimate against measurement, compound 4: 1.9-fold (0.27 log units) above, within the range that was stated.
By their numbers in this assay, from the lowest: compound 2; then compounds 4 and 3 (each within the scatter of the next).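

In this assay, for the compounds shown here, the only step at this position runs a 1.5-fold lower number from compound 3 to compound 4 (0.18 log units; within the scatter) as methyl replaces hydrogen on an aromatic carbon, ortho to a large group and meta to a methyl group. Going by these compounds alone, the change from 2-methylphenyl to 2,6-dimethylphenyl therefore leaves the number unchanged within the usual scatter, which the earlier compounds could not show, since no measured pair among them differed in one place. No measurement shown here gives a reason for this result.

Going by these compounds, whether chlorine, a methoxy group or a dimethylamino group in this same place would also leave the number unchanged remains open. So does whether an added methyl would behave in the same way with a different group at the other end of the chain, such as the one in compound 1.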